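The source may report more compounds than this note shows. Statements on the series, on what has been measured and on what is new or still open speak of the compounds shown alone.

Measured so far in a functional assay on PBMC cells (Homo sapiens) for inhibition, read by HTRF, with stated times of 15 min and 24 h; on this read-out higher numbers stand for weaker inhibition and lower numbers for stronger inhibition:
- Compound 1 `O=C(Nc1ccc2c(c1)B(O)OC2)c1ccccc1F`: > 10000 nM
- Compound 2 `COc1ccccc1C(=O)Nc1ccc2c(c1)B(O)OC2`: > 100000 nM
- Compound 3 `O=C(Nc1ccc2c(c1)B(O)OC2)c1cc(C(F)(F)F)ccc1F`: > 100000 nM

All three entries are limits, not numbers. Compound 1 therefore has no numerical position, only its limit of > 10000 nM.

The change to compound 4 `O=C(Nc1ccc2c(c1)B(O)OC2)c1cccc(Cl)c1F` is chloro in place of hydrogen on an aromatic carbon, ortho to a fluoro group and meta to a large group.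

The closer precedent is a step that the two limits leave unreadable from compound 1 to compound 3, trifluoromethyl in place of hydrogen on an aromatic carbon. Less direct is a step that the two limits leave unreadable from compound 1 to compound 2, methoxy in place of fluoro on an aromatic carbon. Going by the values given here, neither gives a size or a direction, so no step of definite size or direction can be expected in this assay. Compound 4 is expected to remain weak and may also be reported only as a limit. The expected step is a step that the limit leaves unreadable from compound 1 to compound 4. For compound 4 the estimated value is 20000 nM, with an expected range of 3000 nM to 100000 nM.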

Compound 4, half-maximal inhibitory concentration: > 100000 nM
Compound 4: no number, only a limit; the forecaster's own chance of this, stated with the estimate: 70%; middle value at least 5.0-fold (0.69 log units) from the limit.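

Going by these compounds alone, compound 1 and compound 4 are both reported only as limits, so no step between them can be read in this assay. The compounds shown leave open whether chloro in place of hydrogen on an aromatic carbon changes inhibition at all, and what number any of the four compounds would have.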